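Adding a methyl to the acid chain of compound 2

This account rests on a few compounds, and the source may have more. Where it says the series, first, only, none or still open, it means among the compounds named here.

Compound 1 `COc1cc(OC)c(NC(=O)Cn2nc(CC(=O)O)c3ccccc32)cc1Cl` gives < 55 mL/min/kg (a limit)
Compound 2 `O=C(O)Cc1nn(Cc2cn3cc(OCC4CC4)c(Cl)cc3n2)c2ccccc2c1=O` gives < 51.7 mL/min/kg (a limit)

In an ADME assay on microsomes from liver (Mus musculus) for metabolic stability (a higher number here means faster removal of the compound, a lower number slower removal), compound 2 gives < 51.7 mL/min/kg as a limit and not as a number. Going to compound 3 `C[C@H](C(=O)O)c1nn(Cc2cn3cc(OCC4CC4)c(Cl)cc3n2)c2ccccc2c1=O` turns carboxymethyl into 1-carboxyethyl, and methyl in place of hydrogen on a saturated chain carbon bound to an aromatic carbon and a carbonyl carbon sums up that swap. Among the compounds with values here, no measured pair shows such a change, so no shift beyond the usual scatter is expected in this assay for this compound. The expected move is a step that the limit leaves unreadable from compound 2 to compound 3 and it stays within that scatter. For compound 3 the estimate is 35 mL/min/kg with an expected range of 15 mL/min/kg to 60 mL/min/kg overall.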

Compound 3, clearance: < 53.4 mL/min/kg
Compound 3 was reported as a limit; the forecaster's own chance of this, stated with the estimate: 60%; the middle value is on the limit's open side.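

Within the data shown here, compound 2 and compound 3 are both reported only as limits, so no step between them can be read. The compounds shown leave open whether methyl in place of hydrogen shifts the true clearance in this assay at all.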